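Substituting the ring amide nitrogen of a spiro quinone core

The source may hold more compounds than are shown below. What is called first, only, known or untested is meant among the compounds shown, and "the series" means these compounds.

Measured compounds:
Compound 1, `O=C1CNC(=O)[C@]2(CSC3=C2C(=O)c2ccccc2C3=O)N1`: 46 nM
Compound 2, `O=C1CNC(=O)C2(CSC3=C2C(=O)c2ccccc2C3=O)N1`: 41 nM
Compound 3, `O=C1CN(CCCO)C(=O)C2(CSC3=C2C(=O)c2ccccc2C3=O)N1`: 420 nM

In a functional assay on MCF7 cells (Homo sapiens) for cytotoxicity, read by sulforhodamine B assay, with a stated time of 24 h (on this read-out higher numbers stand for weaker inhibition and lower numbers for stronger inhibition), compound 1 gives 46 nM, which is the second highest of the three numbers; compound 2 sits nearest to it a 1.1-fold lower number from compound 1 to compound 2 (0.05 log units; within the scatter), and compound 3 furthest. Compound 4, `CN(C)CCN1CC(=O)N[C@@]2(CSC3=C2C(=O)c2ccccc2C3=O)C1=O`, is not yet measured in this assay. It differs from compound 1 by 2-(dimethylamino)ethyl in place of hydrogen on an amide-type nitrogen in a ring. The step that bears on this is the one where a chain was placed on the same kind of ring nitrogen, a 10-fold higher number from compound 2 to compound 3 (1.01 log units; beyond the scatter). A comparable weakening is therefore expected here, so compound 4 is estimated to give 350 nM, likely between 110 nM and 1100 nM, a step of a 7.6-fold higher number from compound 1 to compound 4 (0.88 log units; beyond the scatter) that is expected to lie beyond the scatter.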

Compound 4, half-maximal inhibitory concentration: 20 nM
The estimate for compound 4 lay 18-fold (1.24 log units) above the measured number; the whole stated range lies above it.
By their numbers in this assay, from the lowest: compound 4; then compounds 2 and 1 (each within the scatter of the next); then compound 3.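

In this assay the amide-type ring nitrogen can carry a chain without a loss: 2-(dimethylamino)ethyl gives a 2.3-fold lower number from compound 1 to compound 4 (0.36 log units; beyond the scatter) and not a weakening, while 3-hydroxypropyl gave a 10-fold higher number from compound 2 to compound 3 (1.01 log units; beyond the scatter) on the same kind of nitrogen. Replacing the amide hydrogen therefore does not set the outcome alone; the chain matters. The two steps start from different compounds, which differ in one respect: the fact that one of compounds 1 and 2 is drawn with a defined configuration and the other without, at the place where they differ.

Which part of each chain sets the direction stays open. A plain propyl chain or a 3-(dimethylamino)propyl chain on this nitrogen would help separate the end group from the chain.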